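The source may hold more compounds than are shown below. What is called first, only, known or untested is meant among the compounds shown, and "the series" means these compounds.

Measured compounds:
Compound 1 `NC(=O)[C@@H](CCC(F)(F)F)N(CC1COC1)S(=O)(=O)c1ccc(Cl)cc1`: 25.4 10^-6 cm/s
Compound 2 `CC1(C)C[C@H](CN([C@H](CCC(F)(F)F)C(N)=O)S(=O)(=O)c2ccc(Cl)cc2)O1`: 18.1 10^-6 cm/s

In an ADME assay on MDCKII-LE cells (Canis lupus familiaris) for permeability, read by transwell migration, in the apical to basolateral direction (a lower number here means that the compound crosses the layer more slowly, a higher number that the compound crosses the layer faster), compound 1 gives 25.4 10^-6 cm/s. For the measured compounds named here, only one other measured number stands beside it, and the two lie within the scatter of each other, so compound 1 holds no real separation from compound 2.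

The next compound to read is compound 3 `CC1(C)CO[C@H]1CN([C@H](CCC(F)(F)F)C(N)=O)S(=O)(=O)c1ccc(Cl)cc1`, not yet measured. Its difference from compound 1 is 3,3-dimethyloxetan-2-yl in place of oxetan-3-yl on a saturated chain carbon bound to a sulfonamide nitrogen. In short, 3,3-dimethyloxetan-2-yl stands in place of oxetan-3-yl on a saturated chain carbon bound to a sulfonamide nitrogen.

Going by the values given here, the one measured step that bears on this change is a 1.4-fold lower number from compound 1 to compound 2 (0.15 log units; within the scatter), where 4,4-dimethyloxetan-2-yl enters at the same place. Among the compounds with values here, that step stays within the scatter, but it is a single step, and no measurement yet covers the 3,3-dimethyloxetan-2-yl group itself. A step beyond the scatter in this assay is therefore not expected, and any drift is expected to be small and downward.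

The expected step is a 1.3-fold lower number from compound 1 to compound 3 (0.10 log units; within the scatter). For compound 3 the estimated value is 20 10^-6 cm/s, with an expected range of 11 10^-6 cm/s to 32 10^-6 cm/s.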

Compound 3, apparent permeability: 26.4 10^-6 cm/s
For compound 3 the middle estimate is 1.3-fold (0.12 log units) below the measured one, and the stated range covers the measured number.
By their numbers in this assay, from the lowest: compounds 2, 1 and 3 (each within the scatter of the next).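

In this assay, the change on a saturated chain carbon bound to a sulfonamide nitrogen reads a 1.0-fold higher number from compound 1 to compound 3 (0.02 log units; within the scatter), so a second dimethyl-substituted oxetane, 3,3-dimethyloxetan-2-yl, now stands alongside 4,4-dimethyloxetan-2-yl with no separation from oxetan-3-yl. The direct comparison of the two dimethyl groups, 3,3-dimethyloxetan-2-yl in place of 4,4-dimethyloxetan-2-yl, reads a 1.5-fold higher number from compound 2 to compound 3 (0.16 log units; within the scatter), which shows that at this place the two arrangements of the methyl groups are not separated in this read-out either. No supporting measurement accompanies these numbers, so nothing here accounts for how closely the three compounds sit together.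

All three groups at this place are neutral oxetanes, so the series gives no reading on whether a primary amine, a carboxylic acid or a plain longer alkyl chain at the same carbon would produce a step beyond the scatter. The shown compounds also hold the 4-chlorophenyl sulfonamide and the trifluoromethyl-ended chain constant, so whether the same flat reading would hold with either of those parts replaced remains open.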